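A Smaller Heteroaromatic Ring in Place of Dimethylphenyl

The compounds below may be only part of what the source reports. "The series", "measured", "known", "first", "only" and "open" are said of these compounds alone.

For the measured compounds named here, compound 3 `COc1ccc2nc(C)cc(OCC(=O)Nc3c(C)cccc3C)c2c1` stands lowest of the three compounds measured so far in a physicochemical assay for lipophilicity, read by HPLC, in phosphate buffer, measured as chromatographic lipophilicity, at pH 7.4 (on this read-out lower numbers stand for lower lipophilicity and higher numbers for higher lipophilicity), where compound 3 gives 4.55. Its nearest neighbour is compound 2 `COc1ccc2nc(C)cc(OC(C)(C)C(=O)Nc3cc(C)cc(C)c3)c2c1`, which in this assay gives 6.37, a number higher than that of compound 3 by more than the scatter. Furthest away is compound 1 `Cc1cc(C)cc(NC(=O)COc2cc(C)nc3ccc(OC(F)(F)F)cc23)c1`, which in this assay gives 6.79, again higher by more than the scatter. None of these three compounds differ from one another in only one place, so their values can only be set side by side, and no single change can be read from them.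

Compound 4 `COc1ccc2nc(C)cc(OCC(=O)Nc3nccs3)c2c1` has not yet been measured. It differs from compound 3 in a single place: 1,3-thiazol-2-yl in place of 2,6-dimethylphenyl on an amide-type nitrogen. An aromatic ring of carbon only gives way to a five-membered aromatic ring with two hetero atoms, and the new group brings hydrogen-bond acceptors where the old one had none. Going by the values given here, with no measured pair showing this kind of exchange, the expectation rests on the change alone: a downward step, clearly beyond the scatter. The expected step is a number 1.65 log units lower from compound 3 to compound 4 (beyond the scatter). For compound 4 the estimate in this assay is 2.9, with a range from 2.2 to 3.6.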

Compound 4, distribution coefficient: 3.2
For compound 4 the middle estimate is 0.30 log units below the measured one; the measured number falls inside the stated range.
By their numbers in this assay, from the lowest: compound 4; then compound 3; then compound 2; then compound 1.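

For the compounds shown here, the exchange of 2,6-dimethylphenyl for 1,3-thiazol-2-yl on an amide-type nitrogen gives the only single-place step in this set: in this assay the result is a number 1.35 log units lower from compound 3 to compound 4 (beyond the scatter), with the rest of the molecule unchanged. The earlier compounds shown here could only be set side by side, whereas this pair shows that the group at this one place can by itself shift the read-out well beyond ordinary repeat variation. Several things change together in this exchange, as a six-membered aromatic ring of carbon only gives way to a five-membered aromatic ring with two hetero atoms, and nothing measured here explains the drop or assigns it to any one of those differences.

A plain phenyl or a pyridin-2-yl group at the same place would help to separate the part played by the two methyl groups from that of the ring exchange, and the compounds shown include neither. As far as these compounds go, it also remains open whether 1,3-thiazol-2-yl would bring a step of similar size on the core of compound 1 or of compound 2.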